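A few compounds are considered here, and "the series" means these few. Any claim that something is new, unique, unknown or untested is made for them only; others in the source may bear on it.

Measured so far:
Compound 1, `CCCCCCCC(CCO)n1cnc2c(N)ncnc21`: in a functional assay on SW480 cells (Homo sapiens) for antiproliferative activity, read by MTT assay, with a stated time of 48 h (on this read-out lower numbers stand for stronger inhibition and higher numbers for weaker inhibition), compound 1 gives only a limit, > 50000 nM.
Compound 2, `CCCCCCCC(CCO)n1cnc2c(N)nc(Cl)nc21`: in this assay compound 2 gives only a limit, > 50000 nM.
Compound 3, `CCCCCCCCC(CCO)n1cnc2c(Cl)ncnc21`: in this assay compound 3 gives 1370 nM.

Compound 3 is the only one of the three with a number; the other two values are limits (the limit of > 50000 nM in this assay, at which 2 of the 3 values shown sit). The change from compound 1 to compound 2 is chloro in place of hydrogen on an aromatic carbon. Its step, a step that the two limits leave unreadable from compound 1 to compound 2, cannot be read because both values sit at the limit of > 50000 nM in this assay, at which 2 of the 3 values shown sit.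

Compound 4, `CCCCCCCCC(CCO)n1cnc2c(Cl)nc(Cl)nc21`, is not yet measured. It differs from compound 3 by chloro in place of hydrogen on an aromatic carbon. This is the same kind of change as from compound 1 to compound 2, though the surroundings differ: in compound 4 the chloro enters meta to a chloro group, in compound 2 meta to an amino group. How the core of compound 3 differs from the core of compound 1 is not broken down here.

The measured step that the two limits leave unreadable from compound 1 to compound 2 offers no readable size, so the expectation rests on compound 3 alone at 1370 nM. Compound 4 is expected to give about 1500 nM in this assay, most likely between 500 nM and 5000 nM. The expected step, a 1.1-fold higher number from compound 3 to compound 4 (0.04 log units; within the scatter), is estimated to stay within the usual scatter.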

Compound 4, half-maximal inhibitory concentration: 24000 nM
Beside the measured number, compound 4's estimate is 16-fold (1.20 log units) below it; measured number outside the range, above it.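

In this assay, chloro in place of hydrogen on the aromatic carbon between two ring nitrogen atoms gives an 18-fold higher number from compound 3 to compound 4 (1.24 log units; beyond the scatter), so on the core of compound 3 this change weakens inhibition clearly. The same change from compound 1 to compound 2 cannot be read, because both values are limits and not numbers: the limit of > 50000 nM in this assay, at which 2 of the 4 values shown sit. This single pair therefore gives the size of the change on the core of compound 3 only, and does not show that it carries over to the core of compound 1. From the compounds shown here alone, it remains open whether a bromo or a methoxy group in the same place would act as chloro does. Going by these compounds, a longer chain on the core of compound 4 also remains open.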